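A few compounds are considered here, and "the series" means these few. Any claim that something is new, unique, unknown or untested is made for them only; others in the source may bear on it.

Three compounds share one core and differ only in the aryl group that hangs from an oxygen on a saturated carbon. In a functional assay on CHO cells for agonist activity at Free fatty acid receptor 1 (Homo sapiens), read by FLIPR and calcium flux, tested at 1 uM (on this read-out higher numbers stand for an effect only at larger amounts of compound and lower numbers for an effect already at smaller amounts), compound 1 `O=C(O)CCc1ccc(NC(=O)c2nnc(COc3ccc(F)cc3)s2)cc1` gives 5390 nM, compound 2 `Cc1ccc(C)c(OCc2nnc(C(=O)Nc3ccc(CCC(=O)O)cc3)s2)c1` gives 1530 nM, and compound 3 `O=C(O)CCc1ccc(NC(=O)c2nnc(COc3cccc(Cl)c3)s2)cc1` gives 1570 nM. Going by the values given here, compound 3 thus stands second highest of the three numbers, though its gap to compound 2 is within the scatter, while a 3.4-fold lower number from compound 1 to compound 3 (0.54 log units; beyond the scatter) and a 3.5-fold lower number from compound 1 to compound 2 (0.55 log units; beyond the scatter) both mark compound 1 as the one needing the most compound.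

Compound 4 `Cc1cccc(OCc2nnc(C(=O)Nc3ccc(CCC(=O)O)cc3)s2)c1` differs from compound 3 by methyl in place of chloro on an aromatic carbon. The step that bears most on this change is a 1.0-fold higher number from compound 2 to compound 3 (0.01 log units; within the scatter): a methyl-bearing aryl and a chloro-bearing aryl on the same oxygen gave numbers that cannot be told apart. A methyl in place of the chloro is therefore expected to leave the number roughly where it is, a 1.0-fold lower number from compound 3 to compound 4 (0.02 log units; within the scatter), and compound 4 is estimated at 1500 nM, within a range from 700 nM to 3500 nM.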

Compound 4, half-maximal effective concentration: 3260 nM
Compound 4: middle estimate off by 2.2-fold (0.34 log units), on the low side; the measured number falls inside the stated range.
By their numbers in this assay, from the lowest: compounds 2 and 3 (each within the scatter of the next); then compounds 4 and 1 (each within the scatter of the next).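

At this place on the ring, meta to a large group, chloro and methyl are not interchangeable, although they have the same heavy-atom count: the exchange gives a 2.1-fold higher number from compound 3 to compound 4 (0.32 log units; beyond the scatter). Going by these compounds alone, the match between compound 2 and compound 3 therefore depended on the second methyl of the 2,5-dimethylphenyl group, since removing it gives (a 2.1-fold higher number from compound 2 to compound 4 (0.33 log units; beyond the scatter)), while the single methyl leaves the number not clearly separated from that of the 4-fluorophenyl compound (a 1.7-fold lower number from compound 1 to compound 4 (0.22 log units; within the scatter)). No measurement available here accounts for these shifts.

The compounds shown leave open how a methoxy or a trifluoromethyl at this same place would read. As far as these compounds go, it also remains open whether a 2,5-dichlorophenyl group would match the 2,5-dimethylphenyl group of compound 2.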